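This account rests on a few compounds, and the source may have more. Where it says the series, first, only, none or still open, it means among the compounds named here.

Of the compounds shown here, three built on one shared core have been measured in a functional assay on WI-38 VA13 cells (Homo sapiens) for cytotoxicity; on this read-out lower numbers stand for an effect already at smaller amounts and higher numbers for an effect only at larger amounts of compound. Compound 1 `O=C(Nc1ccc2nc(NC(=O)C3CC3)sc2c1)c1c(Cl)cccc1Cl` gives 0.013 ug/mL. Compound 2 `CC(=O)Nc1nc2ccc(NC(=O)c3c(Cl)cccc3Cl)cc2s1` gives 0.6 ug/mL. Compound 3 `CC(C)(C)OC(=O)Nc1nc2ccc(NC(=O)c3c(Cl)cccc3Cl)cc2s1` gives 0.027 ug/mL, the second highest of the three numbers. Compound 4 `O=C(Nc1nc2ccc(NC(=O)c3c(Cl)cccc3Cl)cc2s1)Oc1ccccc1` has not yet been measured; it differs from compound 3 by phenyl in place of tert-butyl on an oxygen next to a carbonyl group. Among the measured steps, a 22-fold lower number from compound 2 to compound 3 (1.35 log units; beyond the scatter) and a 2.1-fold higher number from compound 1 to compound 3 (0.32 log units; beyond the scatter) both exchange the group on the carbonyl carbon itself rather than the group on the oxygen, so neither matches this change directly and no measured step bears on it closely. The expectation for compound 4 is therefore a step of a 1.1-fold higher number from compound 3 to compound 4 (0.05 log units; within the scatter) in this assay, not beyond the scatter. Compound 4 is expected to give about 0.03 ug/mL, within a range from 0.008 ug/mL to 0.12 ug/mL.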

Compound 4, half-maximal effective concentration: 1.1 ug/mL
Compound 4: the middle estimate sits 37-fold (1.56 log units) below what was measured; the whole stated range lies below it.
By their numbers in this assay, from the lowest: compound 1; then compound 3; then compounds 2 and 4 (each within the scatter of the next).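

Exchanging tert-butyl for phenyl on an oxygen next to a carbonyl group is a decisive change in this assay, giving a 41-fold higher number from compound 3 to compound 4 (1.61 log units; beyond the scatter). Phenoxy on the carbonyl carbon behaves like methyl, with a 1.8-fold higher number from compound 2 to compound 4 (0.26 log units; within the scatter), and stands far from cyclopropyl, with an 85-fold higher number from compound 1 to compound 4 (1.93 log units; beyond the scatter). No measurement shown offers an explanation for this. The compounds shown leave open whether the rise comes from the aromatic ring itself or from losing tert-butyl. Cyclohexyl or benzyl on that oxygen would help separate these two readings.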